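The compounds below may be only part of what the source reports. "The series", "measured", "known", "first", "only" and "open" are said of these compounds alone.

Compound 2 `COc1ccccc1OCc1cc(C)nc(-c2ccccn2)n1` gives 2000 nM in a functional assay on cells for antagonist activity at Free fatty acid receptor 1 (Homo sapiens), read by TR-FRET and inositol phosphate accumulation, with a stated time of 2 h (a higher number here means a weaker inhibitor, a lower number a stronger inhibitor), the higher of the two numbers in hand. For the measured compounds named here, its nearest neighbour is compound 1 `Cc1cc(COc2ccccc2)nc(-c2ccccn2)n1`, which gives 794 nM in this assay; the only measured step, a 2.5-fold higher number from compound 1 to compound 2 (0.40 log units; beyond the scatter), shows what the methoxy at that position costs, a modest loss beyond the scatter. Compound 3 `Cc1cc(COc2ccccc2C#N)nc(-c2ccccn2)n1` differs from compound 2 by cyano in place of methoxy on an aromatic carbon. Going by the values given here, no measured pair shows a cyano at this position, so the step from compound 1 to compound 2 is the only guide: one group at that position has already been exchanged for another of the same heavy-atom count, and the cost of the methoxy was modest. Compound 3 is therefore expected to land near compound 2, within the scatter, an estimated step of a 1.3-fold lower number from compound 2 to compound 3 (0.10 log units; within the scatter). The expected value for compound 3 in this assay is 1600 nM, with a range from 500 nM to 5000 nM.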

Compound 3, half-maximal inhibitory concentration in the Free fatty acid receptor 1 assay: 10000 nM
Beside the measured number, compound 3's estimate is 6.3-fold (0.80 log units) below it; the whole stated range lies below it.
By their numbers in the Free fatty acid receptor 1 assay, from the lowest: compound 1; then compound 2; then compound 3.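

In the Free fatty acid receptor 1 assay two groups with the same heavy-atom count and the same count of hydrogen-bond acceptors prove far from interchangeable on this aromatic carbon: cyano in place of methoxy gives a 5.0-fold higher number from compound 2 to compound 3 (0.70 log units; beyond the scatter) and cyano in place of hydrogen gives a 13-fold higher number from compound 1 to compound 3 (1.10 log units; beyond the scatter) while methoxy in place of hydrogen gives a 2.5-fold higher number from compound 1 to compound 2 (0.40 log units; beyond the scatter) so that both groups shown raise the number over hydrogen, cyano by more. The same exchange in a physicochemical assay for lipophilicity, at pH 7.4 (a higher number here means a more lipophilic compound, a lower number a more polar compound), gives a number 0.20 log units higher from compound 2 to compound 3 (within the scatter) with compound 2 at 2.5 and compound 3 at 2.7 and so the two compounds separate clearly in only one of the two read-outs. Nothing at hand accounts for the gap between methoxy and cyano at this place.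

Going by these compounds, in the Free fatty acid receptor 1 assay it remains open whether any group at this place would give a lower number than compound 1 at 794 nM rather than a higher one. On these data alone, it also remains open whether an amine, a carboxylic acid or a simple fluorine would sit nearer to methoxy or to cyano.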